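A few compounds are considered here, and "the series" means these few. Any claim that something is new, unique, unknown or untested is made for them only; others in the source may bear on it.

Compound 1 `COc1cccc(/C=C2\CCC/C(=C\c3ccccc3Cl)C2=O)c1OC` gives 44200 nM
Compound 2 `COc1ccccc1/C=C1\CCC/C(=C\c2cccc(OC)c2OC)C1=O` gives 31300 nM
Compound 3 `COc1cccc(/C=C2\CCC/C(=C\c3ccc(O)cc3)C2=O)c1OC` gives > 50000 nM (a limit of the assay, not a number)

All three were tested in an ADME assay on NHDF cells (Homo sapiens) for cytotoxicity, read by MTT assay, with a stated time of 72 h; on this read-out higher numbers stand for weaker inhibition and lower numbers for stronger inhibition. Compound 3 therefore has no exact position on this scale, only a limit (the limit of > 50000 nM in this assay, at which 1 of the 3 values shown sits).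

Compound 4 `COc1cccc(/C=C2\CCC/C(=C\c3ccc(Cl)cc3Cl)C2=O)c1OC` keeps the core of compound 3 and changes one group on a double-bonded chain carbon bound to a double-bonded ring carbon (2,4-dichlorophenyl in place of 4-hydroxyphenyl on a double-bonded chain carbon bound to a double-bonded ring carbon).

Among the measured compounds shown here, three measured steps bear on this change. Two of them place 4-hydroxyphenyl at the same position (an at least 1.1-fold higher number from compound 1 to compound 3 (0.05 log units; that floor lies within the scatter); an at least 1.5-fold higher number from compound 2 to compound 3 (0.20 log units; that floor lies within the scatter)). Both are only floors, and both floors lie within the scatter. The third step (a 1.4-fold lower number from compound 1 to compound 2 (0.15 log units; within the scatter)) also stays within the scatter, so no measured change here has clearly moved the number.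

Compound 1, which carries 2-chlorophenyl at this position, gives a real number (44200 nM), and this is the closest guide to a ring bearing chlorine. A modest move toward a lower number is therefore expected, though it may not exceed the scatter, and compound 4 could also reach the limit in this assay. The expected step is small (an at least 1.4-fold lower number from compound 3 to compound 4 (0.15 log units; that floor lies within the scatter)). The estimated value for compound 4 is 35000 nM, with an expected range from 17000 nM to 50000 nM.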

Compound 4, half-maximal inhibitory concentration: 49200 nM
Compound 4: middle estimate off by 1.4-fold (0.15 log units), on the low side; the range from low to high includes it.
By their numbers in this assay, from the lowest: compounds 2, 1 and 4 (each within the scatter of the next). At a limit, above all of these: compound 3.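

In this assay, chloro in place of hydrogen on an aromatic carbon gives a 1.1-fold higher number from compound 1 to compound 4 (0.05 log units; within the scatter), so the extra chlorine on this ring does not clearly move the number. Swapping in 2,4-dichlorophenyl for 2-methoxyphenyl on the double-bonded chain carbon gives a 1.6-fold higher number from compound 2 to compound 4 (0.20 log units; within the scatter), so compounds 1, 2 and 4, with three different rings at this place, cannot be told apart here, and the ring changes tried so far among them have not clearly moved the cell result. 2,4-Dichlorophenyl in place of 4-hydroxyphenyl at this place gives an at least 1.0-fold lower number from compound 3 to compound 4 (0.00 log units; that floor lies within the scatter), but this step gives only a floor, because the value of compound 3 is a limit and not a number: the limit of > 50000 nM in this assay, at which 1 of the 4 values shown sits.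

Nothing shown reveals whether any group at this place can shift the number beyond the scatter, or how far above its limit compound 3 really lies. Going by these compounds, an amine or a carboxylic acid on this ring, or a longer chain in place of the ring, would test this place with groups unlike the chloro, methoxy and hydroxy groups seen here, and their outcome remains open.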